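From hydroxymethyl to methyl in a small series

The source may report more compounds than this note shows. Statements on the series, on what has been measured and on what is new or still open speak of the compounds shown alone.

In an ADME assay on the whole organism (Rattus norvegicus, strain Wistar Han) for pharmacokinetics, read by LC-MS, with stated times of 1 h and 7 h, at a dose of 1 mg/kg by the intravenous route (a lower number here means that more of the compound stays in the plasma, a higher number that more of the compound sits outside the plasma), compound 2 `CNC(=O)c1cc(C(=O)NC2CC2)cc2c1O[C@H](CO)[C@H]2c1ccccc1` gives 1.4 L/kg. Compound 1 `CNC(=O)c1cc(C(=O)N[C@@H]2C[C@H]2CO)cc2c1O[C@H](CF)[C@H]2c1ccccc1` gives 1.7 L/kg, and compound 3 `CNC(=O)c1cc(C(=O)NCCC[C@H]2OC[C@H](N)CO2)cc2c1O[C@H](CF)[C@H]2c1ccccc1` gives 2.1 L/kg. These three numbers all lie within the scatter of one another, so no order among them can be read, and compound 2 stands level with the other two.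

Compound 4 `CNC(=O)c1cc(C(=O)NC2CC2)cc2c1O[C@H](C)[C@H]2c1ccccc1` differs from compound 2 by a single edit: hydrogen in place of hydroxy on a saturated chain carbon bound to a saturated ring carbon. In simple terms, hydroxymethyl becomes methyl.

Within the data shown here, only one measured step changes a single place, and it is a 1.2-fold higher number from compound 1 to compound 3 (0.09 log units; within the scatter). That step exchanges a group on an amide-type nitrogen and stays within the scatter. Among the measured compounds shown here, no measured step removes a hydroxy, so it offers only a loose guide here, and the size of this edit remains untested.

In this assay, the expected result is a 1.2-fold higher number from compound 2 to compound 4 (0.08 log units; within the scatter), which means no expected change beyond the scatter. For compound 4 the estimated value is 1.7 L/kg, with an expected range from 1 L/kg to 2.9 L/kg.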

Compound 4, volume of distribution at steady state: 2.3 L/kg
The estimate for compound 4 lay 1.4-fold (0.13 log units) below the measured number, and the stated range covers the measured number.
By their numbers in this assay, from the lowest: compounds 2, 1, 3 and 4 (each within the scatter of the next).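

In this assay, the first measured edit at this saturated chain carbon, hydrogen in place of hydroxy, gives a 1.6-fold higher number from compound 2 to compound 4 (0.22 log units; within the scatter). At this place, then, the hydroxy can leave, and its hydrogen-bond donor and acceptor with it, without the number moving beyond the usual scatter. No measurement shown here offers an explanation for the two numbers.

The compounds shown leave open whether a different group at this place, such as an amine or a longer chain in place of the hydroxymethyl, would give a step beyond the scatter. They also leave open whether hydrogen in place of hydroxy would read the same with another group on the amide-type nitrogen than the three-membered carbon ring of compound 2 and compound 4.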